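From an aryl to a benzyl group on the ring nitrogen

This account rests on a few compounds, and the source may have more. Where it says the series, first, only, none or still open, it means among the compounds named here.

Compound 2 `CCCn1c(=O)[nH]c2nc(-c3ccc(S(=O)(=O)N4CCN(c5cccc(F)c5)CC4)cc3)[nH]c2c1=O` stands highest of the two numbers in an assay on CHO cells for displacement of a labelled ligand from adenosine receptor A3 (Homo sapiens), read by scintillation counting, with a stated time of 45 min, tested at 1 uM, in the presence of a further agent that is not named here (a higher number here means more inhibition at the concentration tested (going by the name of the read-out), a lower number less inhibition), where compound 2 gives 44%. Its nearest neighbour, compound 1 `CCCn1c(=O)[nH]c2nc(-c3ccc(S(=O)(=O)N4CCN(c5ccccc5Br)CC4)cc3)[nH]c2c1=O`, gives 20%. Going by the values given here, the one measured step, a number 24 percentage points higher from compound 1 to compound 2 (beyond the scatter), shows that the group on the ring nitrogen moves the reading by a modest amount. Compound 3 `CCCn1c(=O)[nH]c2nc(-c3ccc(S(=O)(=O)N4CCN(Cc5ccc(Br)c(F)c5)CC4)cc3)[nH]c2c1=O` differs from compound 2 by 4-bromo-3-fluorobenzyl in place of 3-fluorophenyl on an amine nitrogen in a ring. Among the compounds with values here, no measured step covers a benzyl group or a bromine returning alongside fluorine, so the direction is uncertain. A modest step of a number 9 percentage points lower from compound 2 to compound 3 (within the scatter) is expected. Compound 3 is estimated at 35%, between 10% and 60%.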

Compound 3, a percentage reported as inhibition, at one concentration (the size of the read-out at that concentration, not a potency): 27%
Beside the measured number, compound 3's estimate is 8 percentage points above it; measured number inside the range.
By their numbers in this assay, from the lowest: compounds 1 and 3 (each within the scatter of the next); then compound 2.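

In this assay, 4-bromo-3-fluorobenzyl on the amine nitrogen in the ring gives a number 17 percentage points lower from compound 2 to compound 3 (beyond the scatter), so this change lowers the reading from that of the 3-fluorophenyl compound. Set against 2-bromophenyl at the same place, it gives a number 7 percentage points higher from compound 1 to compound 3 (within the scatter), which leaves the two bromine-bearing compounds level and compound 2, without bromine, above both. No measurement shown explains these differences. The compounds shown leave open whether the bromine or the benzyl link accounts for the lower reading. A plain benzyl group, or a 3-fluorobenzyl group, could separate the two.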